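Exchanging the Sulfur-Bearing Group on the Amine Nitrogen

The source may hold more compounds than are shown below. What is called first, only, known or untested is meant among the compounds shown, and "the series" means these compounds.

Compound 1 `C/N=C(\S)NCCCCn1nc(C)ccc1=O` stands highest of the two compounds measured in a functional assay on the whole organism with Rattus norvegicus as the target, at a dose of 100 mg/kg; on this read-out higher numbers stand for more inhibition at the one dose given (going by the name of the read-out) and lower numbers for less inhibition. In this assay compound 1 gives 44.5%, whereas compound 2 `C/N=C(\S)NCCCCCn1nc(C)ccc1=O` gives 3.2%. The step of a number 41.3 percentage points lower from compound 1 to compound 2 (beyond the scatter) accompanied a group of 6 heavy atoms (3 carbon, 2 nitrogen, 1 sulfur; no ring) in place of a group of 5 heavy atoms (2 carbon, 2 nitrogen, 1 sulfur; no ring), on a saturated chain carbon, four bonds along the chain from an aromatic nitrogen.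

Compound 3 `C/N=C(/NC#N)NCCCCn1nc(C)ccc1=O` differs from compound 1 by a group of 6 heavy atoms (3 carbon, 3 nitrogen; no ring) in place of a group of 4 heavy atoms (2 carbon, 1 nitrogen, 1 sulfur; no ring), on an amine nitrogen, on an amine nitrogen whose other neighbours are a saturated chain carbon. Among the measured compounds shown here, the single measured step concerns the chain and not this nitrogen, so no measured step bears on the change; the data give no direct guide. With that uncertainty, compound 3 is expected to give 30% in this assay, with a range from 5% to 60%. The expected step is therefore a number 14.5 percentage points lower from compound 1 to compound 3 (beyond the scatter), a guess rather than a reading of any shown trend.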

Compound 3, a percentage reported as inhibition, in the whole organism at one dose (the size of the read-out at that dose, not a potency): 23.5%
Beside the measured number, compound 3's estimate is 6.5 percentage points above it; low and high end bracket the measured number.
By their numbers in this assay, from the lowest: compound 2; then compound 3; then compound 1.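

Among the compounds shown here, this is the first measured change on the amine nitrogen itself rather than in the chain. In this assay, replacing the sulfur-bearing group with a group that holds no sulfur and carries a triple bond goes with a number 21 percentage points lower from compound 1 to compound 3 (beyond the scatter), so the group on this nitrogen matters for the read-out, though the step is smaller than the one seen on the chain. Sulfur is also not needed for a reading at this dose, since compound 3 still gives 23.5%, and nothing measured here explains why the number falls.

The compounds shown cannot separate the loss of sulfur from the arrival of the nitrile. They also leave open how a urea would read on this amine nitrogen, and whether the same exchange would behave alike on the longer chain of compound 2.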